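Swapping bromo for fluoro on a ceramidase inhibitor

A few compounds are considered here, and "the series" means these few. Any claim that something is new, unique, unknown or untested is made for them only; others in the source may bear on it.

Three compounds share a core carrying a carbamate with a four-carbon chain ending in a phenyl group, and all were tested in an assay on HEK293 cells for inhibition of acid ceramidase (Homo sapiens), with a stated time of 10 min; on this read-out higher numbers stand for weaker inhibition and lower numbers for stronger inhibition. Compound 1 `O=C(NCCCCc1ccccc1)n1c(=O)oc2ccc(Br)cc21` gives 22 nM. Compound 2 `O=C(c1ccc(Cl)cc1)c1ccc2c(c1)oc(=O)n2C(=O)NCCCCc1ccccc1` gives 14 nM, and compound 3 `O=C(NCCCCc1ccccc1)n1c(=O)oc2cc(Cl)c(Cl)cc21` gives 18 nM. The number for compound 1 is the highest of the three, but its gaps to compound 3 and to compound 2 both lie within the usual scatter of this assay, so the three cannot be told apart.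

Compound 4 `O=C(NCCCCc1ccccc1)n1c(=O)oc2ccc(F)cc21` has not yet been measured. Compared with compound 1 it carries a single change: fluoro in place of bromo on an aromatic carbon. The halogen at that position becomes smaller; a single heavy atom is exchanged for another, with no ring, donor, acceptor or charge involved.

Among the measured compounds shown here, no measured pair in this set shows the effect of such a halogen exchange, so the expectation rests on the narrow spread among compounds 1, 2 and 3 alone. The expected change is a modest step toward a higher number of the size a 1.8-fold higher number from compound 1 to compound 4 (0.26 log units; within the scatter). Compound 4 is estimated at 40 nM in this assay, with a likely range from 12 nM to 130 nM.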

Compound 4, half-maximal inhibitory concentration: 12 nM
Beside the measured number, compound 4's estimate is 3.3-fold (0.52 log units) above it; low and high end bracket the measured number.
By their numbers in this assay, from the lowest: compounds 4, 2, 3 and 1 (each within the scatter of the next).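

In this assay, exchanging bromo for fluoro on this aromatic carbon gives a 1.8-fold lower number from compound 1 to compound 4 (0.26 log units; within the scatter), and that step cannot be told apart from repeat-measurement noise. Among the compounds shown here, compounds 1, 2 and 3 contained no pair differing in one place, so their similar numbers could not isolate what any single group contributes; this step is the first direct test of one position, and here two very different halogens give readings that cannot be separated. Nothing measured here offers an explanation for this result.

What the compounds shown leave open is how far this tolerance extends, since a comparison of bromo and fluoro alone cannot show whether the aromatic carbon would give a similar reading with a plain hydrogen, a methoxy group, an amine or a carboxylic acid in the halogen's place. As far as these compounds go, it also remains unknown whether the same exchange would read alike on a core with a shorter or longer chain than the four-carbon one ending in a phenyl group.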